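This account rests on a few compounds, and the source may have more. Where it says the series, first, only, none or still open, it means among the compounds named here.

In an ADME assay on TERT-RPE1 cells (Homo sapiens) for cytotoxicity, read by MTT assay, with a stated time of 72 h (on this read-out higher numbers stand for weaker inhibition and lower numbers for stronger inhibition), three compounds have been measured so far:

Compound 1, `COc1ccc(/C=C2/CN(C)/C(=N/c3ccc(Cl)cc3)S2)cc1`, gives 39600 nM.
Compound 2, `COc1ccc(/C=C2/CN(C)/C(=N/c3ccc(F)cc3)S2)cc1`, gives 42800 nM.
Compound 3, `COc1ccc(/C=C2/CN(C)/C(=N/c3ccc(OC)cc3)S2)cc1`, gives 65900 nM.

Compound 3 sits at the top end of this narrow spread, but a 1.7-fold higher number from compound 1 to compound 3 (0.22 log units; within the scatter) and a 1.5-fold higher number from compound 2 to compound 3 (0.19 log units; within the scatter) both lie within the scatter, so the three compounds cannot really be told apart on these numbers. All three share one core and differ only in the group on the aromatic ring that hangs from the nitrogen.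

Compound 4, `COc1ccc(/C=C2/CN(C)/C(=N/c3ccc(C(F)(F)F)cc3)S2)cc1`, continues this series with a new group at the same position: trifluoromethyl in place of methoxy on an aromatic carbon. Within the data shown here, the steps that bear on it are the three swaps already made at this position, a 1.1-fold higher number from compound 1 to compound 2 (0.03 log units; within the scatter), a 1.7-fold higher number from compound 1 to compound 3 (0.22 log units; within the scatter) and a 1.5-fold higher number from compound 2 to compound 3 (0.19 log units; within the scatter), each of them within the scatter. Among the measured compounds shown here, no measured step involves trifluoromethyl itself, so the expectation rests only on the pattern that changing this group has so far left this assay essentially unchanged. Compound 4 is therefore expected to give a step of a 1.3-fold lower number from compound 3 to compound 4 (0.12 log units; within the scatter), that is, nothing beyond the scatter. The estimate for compound 4 is 50000 nM, with a likely range from 25000 nM to 100000 nM.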

Compound 4, half-maximal inhibitory concentration: 72000 nM
For compound 4 the middle estimate is 1.4-fold (0.16 log units) below the measured one, within the range that was stated.
By their numbers in this assay, from the lowest: compounds 1, 2, 3 and 4 (each within the scatter of the next).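

In this assay, trifluoromethyl in place of methoxy gives a 1.1-fold higher number from compound 3 to compound 4 (0.04 log units; within the scatter) and so swaps a group with one hydrogen-bond acceptor for a group with none and with more heavy atoms, yet the read-out does not move beyond the scatter. The comparisons with the two halogens agree: trifluoromethyl in place of fluoro gives a 1.7-fold higher number from compound 2 to compound 4 (0.23 log units; within the scatter) and trifluoromethyl in place of chloro gives a 1.8-fold higher number from compound 1 to compound 4 (0.26 log units; within the scatter) and so, across all four groups, this position has not yet produced a step beyond the scatter. Nothing available here explains this flat picture.

Going by these compounds, whether an amine, a carboxylic acid or a longer chain at this position would also leave the read-out unchanged stays open. Also open, on these data alone, is whether a change elsewhere on the shared core would give a step beyond the scatter.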